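Adding a Methoxy Group to Compound 1

The source may hold more compounds than are shown below. What is called first, only, known or untested is meant among the compounds shown, and "the series" means these compounds.

Compound 1 `COc1ccc(C(=O)/C=C/c2cc(-c3cc(OC)c(OC)c(OC)c3)n[nH]2)cc1OC` stands lowest of the two numbers at hand: in a functional assay on LOX IMVI cells (Homo sapiens) for cytotoxicity, read by sulforhodamine B assay, with a stated time of 48 h, tested at 1 uM (a higher number here means a weaker effect of the compound at the concentration tested, a lower number a stronger effect), compound 1 gives 73%, while compound 2 `COc1ccc(C(=O)/C=C/c2cc(-c3cc(OC)c(OC)c(OC)c3)n[nH]2)cc1` gives 85%. For the measured compounds named here, the only measured step, a number 12 percentage points higher from compound 1 to compound 2 (beyond the scatter), is modest. Compound 3 `COc1cc(C(=O)/C=C/c2cc(-c3cc(OC)c(OC)c(OC)c3)n[nH]2)cc(OC)c1OC` differs from compound 1 by methoxy in place of hydrogen on an aromatic carbon. The reverse change is expected to lower the number modestly, because a number 12 percentage points higher from compound 1 to compound 2 (beyond the scatter) went with hydrogen in place of methoxy. Compound 3 is therefore estimated at 64%, within 48% to 80%, an expected step of a number 9 percentage points lower from compound 1 to compound 3 (within the scatter).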

Compound 3, a percentage reported as activity, at one concentration (the size of the read-out at that concentration, not a potency): 82%
Compound 3: middle estimate off by 18 percentage points, on the low side; the whole stated range lies below it.
By their numbers in this assay, from the lowest: compounds 1, 3 and 2 (each within the scatter of the next, the first and the last beyond it).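

In this assay, methoxy in place of hydrogen on this carbon, ortho to a methoxy group and meta to a large group, gives a number 9 percentage points higher from compound 1 to compound 3 (within the scatter), so this change cannot be told apart from no change. It therefore does not mirror the earlier change on the same ring, where a number 12 percentage points higher from compound 1 to compound 2 (beyond the scatter) lay beyond the scatter. Nothing measured here bears on the reason for this difference.

The compounds shown leave open how a hydroxyl group, an amine or a longer chain such as ethoxy would behave on this carbon.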